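The compounds below may be only part of what the source reports. "The series", "measured", "known", "first", "only" and "open" are said of these compounds alone.

Compound 1 `COc1cc(C(=O)O)ccc1OCCCCOc1ccc(C(=O)C(C)C)c(O)c1C` is one of a small group of closely related compounds built on a shared core. They were examined in an assay on HEK293 cells for positive allosteric modulation of metabotropic glutamate receptor 3 (Rattus norvegicus), read by thallium flux, with a stated time of 2.5 min; on this read-out higher numbers stand for an effect only at larger amounts of compound and lower numbers for an effect already at smaller amounts. For compound 1 the outcome stands as "not determined" (no result reported), so no number is available for it. The same holds for compound 3 `Cc1cc(C(=O)O)ccc1OCCCCOc1ccc(C(=O)C(C)C)c(O)c1C`, which in this assay gives "not determined" (no result reported). Among the measured compounds shown here, the only compound of the group with a number is compound 2 `Cc1c(OCCCCOc2ccc(C(=O)O)cc2)ccc(C(=O)CC(C)C)c1O`, which in this assay gives 2720 nM. For the measured compounds named here, compound 1 therefore cannot be placed against compound 2 on the numbers; it simply has no result, and no step between measured compounds can be drawn anywhere in this group.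

Compound 4 `COc1cc(C(=O)O)ccc1OCCCCOc1ccc(C(=O)CC(C)(C)C)c(O)c1C` is not yet measured. It differs from compound 1 in one place: neopentyl in place of isopropyl on a carbonyl carbon. Going by the values given here, nothing measured here shows how such a change shifts the read-out, and since compound 1 itself has no number, the only anchor is the value of compound 2. The expectation is that compound 4 stays in the same general region as compound 2, with wide uncertainty in both directions.

Compound 4 is estimated to give about 3000 nM in this assay, expected to fall between 800 nM and 12000 nM.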

Compound 4, half-maximal effective concentration: 310 nM
Compound 4: the middle estimate sits 9.7-fold (0.99 log units) above what was measured; the measured number lies below the stated range.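

No new step can be read: in this assay compound 4 gives 310 nM and compound 1 has no number to set against it. The compounds shown leave open whether neopentyl in place of isopropyl changes the read-out at all, and by how much. Nothing shown here offers an explanation for the value of compound 4.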